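Swapping the aryl group on a shared core

A few compounds are considered here, and "the series" means these few. Any claim that something is new, unique, unknown or untested is made for them only; others in the source may bear on it.

In a functional assay (a higher number here means a weaker inhibitor, a lower number a stronger inhibitor), compound 1 `CC(C)=CCOc1ccc2c(c1)OC(c1ccc(Cl)cc1)CC2=O` gives 6970 nM and compound 2 `CC(C)=CCOc1ccc2c(c1)OC(c1cccc(Br)c1)CC2=O` gives 5280 nM. Within the data shown here, these are the only two measurements so far, and compound 2 stands level with compound 1 within the scatter. Compound 3 `COc1ccc(C2CC(=O)c3ccc(OCC=C(C)C)cc3O2)cc1` carries 4-methoxyphenyl in place of 3-bromophenyl on a saturated ring carbon, next to the ring oxygen (4-methoxyphenyl in place of 3-bromophenyl on a saturated ring carbon). Among the measured compounds shown here, the one measured step at this place is a 1.3-fold lower number from compound 1 to compound 2 (0.12 log units; within the scatter), and it swaps one halogen-bearing phenyl group for another. For the measured compounds named here, no measured compound carries 4-methoxyphenyl, so the data point in no direction, and no step beyond the scatter is expected in this assay. The expected step is a 1.1-fold higher number from compound 2 to compound 3 (0.06 log units; within the scatter). Compound 3 is estimated at about 6000 nM, with an expected range of 2500 nM to 14000 nM.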

Compound 3, half-maximal inhibitory concentration: 10200 nM
The estimate for compound 3 lay 1.7-fold (0.23 log units) below the measured number, and the stated range covers the measured number.
By their numbers in this assay, from the lowest: compounds 2, 1 and 3 (each within the scatter of the next).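

The earlier pair held only halogen-bearing phenyl groups on this saturated ring carbon, and compound 3 shows that 4-methoxyphenyl, whose substituent carries oxygen rather than a halogen, also stays within the scatter in this assay. The change from 3-bromophenyl gives a 1.9-fold higher number from compound 2 to compound 3 (0.29 log units; within the scatter) and methoxy in place of chloro gives a 1.5-fold higher number from compound 1 to compound 3 (0.17 log units; within the scatter) and since both steps lie within the scatter, nothing yet separates these three aryl groups. No evidence is available to explain these numbers.

On these data alone, it remains open whether any group at this position can move the number beyond the scatter, for example a phenyl ring carrying an amine or a carboxylic acid. Also open, as far as these compounds go, is whether an unsubstituted phenyl ring would sit level with these three compounds.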